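The source may hold more compounds than are shown below. What is called first, only, known or untested is meant among the compounds shown, and "the series" means these compounds.

Measured so far in an assay on isolated protein (strain Charles River) for antagonist activity at histamine H2 receptor (Rattus norvegicus); on this read-out higher numbers stand for an effect only at larger amounts of compound and lower numbers for an effect already at smaller amounts:
- compound 1, `Cc1cc(C)c2ccc(=O)n(CCN(C)C)c2n1`, gives 3.93 ug/mL
- compound 2, `Cc1cc(C)c2ccc(=O)n(CCN)c2n1`, gives 33.8 ug/mL
- compound 3, `CCN(CC)CCn1c(=O)ccc2c(C)cc(C)nc21`, gives 1.12 ug/mL

Compound 3 stands lowest of the three numbers in this assay; its nearest neighbour is compound 1, and the step of a 3.5-fold lower number from compound 1 to compound 3 (0.55 log units; beyond the scatter) lies beyond the scatter. The step of an 8.6-fold higher number from compound 1 to compound 2 (0.93 log units; beyond the scatter) went the other way, and the step of a 30-fold lower number from compound 2 to compound 3 (1.48 log units; beyond the scatter) was the largest of the set.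

Compound 4, `Cc1cc(C)c2ccc(=O)n(CC(C)(C)N(C)C)c2n1`, is built from the same atoms as compound 3 but joined differently: 1-(dimethylamino)-1-methylethyl in place of (diethylamino)methyl on a saturated chain carbon bound to an aromatic nitrogen. Two of the measured steps bear on this change. The step of a 3.5-fold lower number from compound 1 to compound 3 (0.55 log units; beyond the scatter) shows that the diethylamino group sits lower than the dimethylamino group, so returning to dimethylamino in compound 4 is expected to undo that part and push the number back up toward compound 1. The step of an 8.6-fold higher number from compound 1 to compound 2 (0.93 log units; beyond the scatter) shows that a smaller amine group gives a clearly higher number. Going by the values given here, no measured compound carries the 1-methylethyl branching on the chain carbon, so nothing in the data says which way that part moves the number. Compound 4 is therefore expected to give a higher number than compound 3, by about a 4.0-fold higher number from compound 3 to compound 4 (0.60 log units; beyond the scatter), landing near 4.5 ug/mL with a range from 1.5 ug/mL to 14 ug/mL.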

Compound 4, half-maximal effective concentration: 10.4 ug/mL
The estimate for compound 4 lay 2.3-fold (0.36 log units) below the measured number; measured number inside the range.
By their numbers in this assay, from the lowest: compound 3; then compound 1; then compound 4; then compound 2.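

In this assay, going by these compounds alone, with the dimethylamino group kept and only the chain altered, 1-(dimethylamino)-1-methylethyl in place of (dimethylamino)methyl gave a 2.6-fold higher number from compound 1 to compound 4 (0.42 log units; beyond the scatter), the first measured change at this place that leaves the amine itself unchanged. Both groups in the step of a 9.3-fold higher number from compound 3 to compound 4 (0.97 log units; beyond the scatter) count the same heavy atoms, yet the numbers lie clearly apart, so among these compounds the way the atoms are joined matters as well as their count, while a 3.3-fold lower number from compound 2 to compound 4 (0.51 log units; beyond the scatter) shows that the new group still gives a lower number than aminomethyl. No measured property accompanies these numbers, so the data offer no explanation for the shifts.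

From the compounds shown here alone, whether a single added methyl on the chain carbon would give part of this rise, and whether diethylamino on the same branched chain would bring the number back toward that of compound 3, remains open. So does the outcome for a longer chain carrying the dimethylamino group, or for a cyclic amine such as piperidine or morpholine in its place.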